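The source may report more compounds than this note shows. Statements on the series, on what has been measured and on what is new or still open speak of the compounds shown alone.

Compound 1, `CCCCC/C=C/C=C/C=N/Nc1nc(N)c2ncn([C@@H]3O[C@H](CO)[C@@H](O)[C@H]3O)c2n1`, gives 2 nM in an assay on CHO-K1 cells for displacement of a labelled ligand from adenosine receptor A1 (Homo sapiens), read by scintillation counting, with a stated time of 60 min; a higher number here means a weaker inhibitor, a lower number a stronger inhibitor. Compound 2, `CSCC/C=N/Nc1nc(N)c2ncn([C@@H]3O[C@H](CO)[C@@H](O)[C@H]3O)c2n1`, reaches only the limit of this assay, > 10000 nM. Compound 3, `Nc1nc(N/N=C/c2ccc(-c3ccccc3)cc2)nc2c1ncn2[C@@H]1O[C@H](CO)[C@@H](O)[C@H]1O`, gives 7860 nM in this assay.

Among the two numbers shown, compound 3 stands at the highest; compound 1 holds the lower number, and the gap between them lies beyond the scatter. Compound 4, `CCCOc1ccc(/C=N/Nc2nc(N)c3ncn([C@@H]4O[C@H](CO)[C@@H](O)[C@H]4O)c3n2)cc1`, differs from compound 3 in one place: propoxy in place of phenyl on an aromatic carbon.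

Going by the values given here, only one measured step is available, and it touches a different part of the molecule: an at least 5000-fold higher number from compound 1 to compound 2 (3.69 log units; beyond the scatter), which sits at the limit of > 10000 nM in this assay, at which 1 of the 3 values shown sits. It shows that the group hanging from the carbon with a double bond to nitrogen can move the number greatly, but it says nothing about an exchange on the aromatic ring itself. Among the compounds with values here, no measured pair shows propoxy against phenyl.

Within the data shown here, with no step bearing directly on this change, compound 4 is expected to stay near compound 3, and the estimated step of a 2.0-fold lower number from compound 3 to compound 4 (0.29 log units; within the scatter) is small. The expected value for compound 4 is 4000 nM, with a range from 600 nM to 15000 nM.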

Compound 4, inhibition constant: > 10000 nM
Compound 4: a limit, no number; the forecaster's own chance of this, stated with the estimate: 25%; middle value at least 2.5-fold (0.39 log units) from the limit.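

In this assay compound 4 gives > 10000 nM, which is a limit and not a number: the limit of > 10000 nM in this assay, at which 2 of the 4 values shown sit. Propoxy in place of phenyl on this aromatic carbon gives an at least 1.2-fold higher number from compound 3 to compound 4 (0.10 log units; that floor lies within the scatter), a floor within the scatter, so this exchange does not bring the number down, but the true size of any rise stays unknown. With an at least 5000-fold higher number from compound 1 to compound 4 (3.69 log units; beyond the scatter), the 4-propoxyphenyl group stays far from the open chain of compound 1, and a second substituent on this ring has now failed to approach that compound.

The step between compound 2 and compound 4 cannot be read, since both values are limits. Going by these compounds, it remains open whether an amine, a carboxylic acid or a longer alkoxy chain on this aromatic carbon would bring the number down.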